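Adding a Methoxy Group to a Lactone Core

The source may report more compounds than this note shows. Statements on the series, on what has been measured and on what is new or still open speak of the compounds shown alone.

Compound 1 `COc1ccc(/C=C/C2CC(=O)C=CO2)cc1OC` and compound 2 `COc1cc(/C=C/C2CC(=O)C=CO2)cc(OC)c1OC` share one core; compound 3 `COc1ccc(/C=C/C2CC=CC(=O)O2)cc1` and compound 4 `COc1ccc(/C=C/C2CC=CC(=O)O2)c(OC)c1` share another, and the difference between the two cores is not broken down here. In an ADME assay on HaCaT cells (Homo sapiens) for inhibition, read by sulforhodamine B assay, with a stated time of 48 h (a lower number here means a stronger inhibitor of growth, a higher number a weaker inhibitor of growth), compound 1 gives 134 uM and compound 2 gives 155 uM, while compound 3 gives 58.8 uM in this assay. The change from compound 1 to compound 2 is methoxy in place of hydrogen on an aromatic carbon, and it made a 1.2-fold higher number from compound 1 to compound 2 (0.06 log units; within the scatter). From compound 3 to compound 4 the same kind of change is made, (methoxy in place of hydrogen on an aromatic carbon), but here the entering group is ortho to a group of 9 heavy atoms and meta to a methoxy group, whereas in compound 2 it is ortho to a methoxy group, meta to a group of 9 heavy atoms and meta to a methoxy group. Because a 1.2-fold higher number from compound 1 to compound 2 (0.06 log units; within the scatter) stayed within the scatter, compound 4 is expected to show a 1.1-fold higher number from compound 3 to compound 4 (0.04 log units; within the scatter). Compound 4 is thus estimated at 65 uM in this assay, between 35 uM and 120 uM.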

Compound 4, concentration for growth inhibition (reported as GI): 15.8 uM
Compound 4: the middle estimate sits 4.1-fold (0.61 log units) above what was measured, outside the stated range (below it).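

In this assay, the entering methoxy group made a 3.7-fold lower number from compound 3 to compound 4 (0.57 log units; beyond the scatter), a clear shift of a kind the same change did not produce on the other core. The step therefore did not carry over unchanged from one core to the other: the same change on two cores in this assay, a 1.2-fold higher number (0.06 log units; within the scatter) from compound 1 to compound 2 and a 3.7-fold lower number (0.57 log units; beyond the scatter) from compound 3 to compound 4, 4.3-fold (0.63 log units) apart, beyond the scatter of two such steps. This does not show whether the core or the place of the methoxy group matters, as the entering groups sit at different places on the aromatic ring and the cores also differ, and these two pairs cannot separate the two.

Still open, from the compounds shown here alone, is how a methoxy group would behave at the same place on both cores. Also open, going by these compounds, is whether a hydroxyl group, a fluorine atom or a longer chain such as ethoxy would follow the same course.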